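Quinoline sulfones: aryl swap on the sulfonyl sulfur

The source may report more compounds than this note shows. Statements on the series, on what has been measured and on what is new or still open speak of the compounds shown alone.

Measured so far:
compound 1 `Cc1ccc(S(=O)(=O)c2cnc3ccc(Cl)cc3c2N2CCC(C)CC2)cc1C` — 84%
compound 2 `CC1CCN(c2c(S(=O)(=O)c3ccc(F)cc3)cnc3ccc(F)cc23)CC1` — 87%

In an assay on isolated protein for displacement of a labelled ligand from metabotropic glutamate receptor 5 (Homo sapiens), with a stated time of 60 min, tested at 1 uM (a lower number here means less inhibition, a higher number more inhibition at the concentration tested (going by the name of the read-out)), compound 2 gives 87%, the higher of the two numbers shown; compound 1 gives 84%, which lies within the usual scatter of that figure, so the two compounds cannot be ordered. Compound 3 `Cc1ccc(S(=O)(=O)c2cnc3ccc(F)cc3c2N2CCC(C)CC2)cc1C` is not yet measured. It differs from compound 2 by 3,4-dimethylphenyl in place of 4-fluorophenyl on a sulfonyl sulfur. Among the compounds with values here, no measured pair isolates this change, so the step from compound 2 to compound 3 is expected to be small, without a clear direction beyond the scatter, as a number 2 percentage points lower from compound 2 to compound 3 (within the scatter) expresses. Compound 3 is therefore expected to reach 85% in this assay, between 72% and 94%.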

Compound 3, a percentage reported as inhibition, at one concentration (the size of the read-out at that concentration, not a potency): 92%
Estimate against measurement, compound 3: 7 percentage points below, within the range that was stated.
By their numbers in this assay, from the lowest: compounds 1, 2 and 3 (each within the scatter of the next).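

In this assay, 3,4-dimethylphenyl in place of 4-fluorophenyl on a sulfonyl sulfur gives a number 5 percentage points higher from compound 2 to compound 3 (within the scatter) and so shows no readable change in the number between the two aryl groups. Fluoro in place of chloro on an aromatic carbon gives a number 8 percentage points higher from compound 1 to compound 3 (within the scatter) and likewise separates nothing. No evidence on hand bears on either step.

Open, on these data alone, is whether a phenyl carrying a carboxylic acid or an amine on the sulfonyl sulfur would keep this inhibition. A single-concentration read-out also leaves any potency order among these compounds unresolved.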